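The source may hold more compounds than are shown below. What is called first, only, known or untested is meant among the compounds shown, and "the series" means these compounds.

Two compounds define the picture so far. Compound 1, `CC(=O)Nc1cc(-c2ccc(OC[C@@](C)(N)CC(C)C)c(F)c2)ccn1`, was measured in an assay on brain (strain C57BL6) for displacement of a labelled ligand from AP2-associated protein kinase 1 (Mus musculus), read by scintillation counting, with a stated time of 1 h (a lower number here means a stronger inhibitor, a higher number a weaker inhibitor), and gave 0.24 nM. Compound 2, `COC(=O)Nc1cc(-c2ccc(OC[C@@](C)(N)CC(C)C)c(C)c2)ccn1`, gave in this assay 0.08 nM, the lowest of the two numbers; compound 1 stands next to it with a higher number, and that gap lies beyond the usual scatter. Among the measured compounds shown here, these two compounds differ in more than one place, so no single step between them can be read.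

Compound 3, `COC(=O)Nc1cc(-c2ccc(OC[C@@](C)(N)CC(C)C)c(F)c2)ccn1`, has not yet been measured. It differs from compound 2 by fluoro in place of methyl on an aromatic carbon. Compound 1 carries the same fluoro in the same place, but with a different group on the shared core, so the two measured values do not separate the effect of this exchange from the other difference. For the measured compounds named here, no step for this change alone is therefore known; the writer expects a small rise in the number, perhaps not beyond the scatter, as the estimated step of a 1.9-fold higher number from compound 2 to compound 3 (0.27 log units; within the scatter) says. Compound 3 is expected to give an inhibition constant of about 0.15 nM, with a range from 0.05 nM to 0.5 nM.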

Compound 3, inhibition constant: 0.2 nM
The estimate for compound 3 lay 1.3-fold (0.12 log units) below the measured number; the range from low to high includes it.
By their numbers in this assay, from the lowest: compound 2; then compounds 3 and 1 (each within the scatter of the next).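

In this assay, the exchange of methyl for fluoro on the aromatic carbon ortho to the (2-amino-2,4-dimethylpentyl)oxy group can now be read alone, with methoxy held on the carbonyl carbon, and it gives a 2.5-fold higher number from compound 2 to compound 3 (0.40 log units; beyond the scatter): a modest step, but one beyond the scatter, in favour of methyl at this position. Among the compounds shown here, the exchange on the carbonyl carbon can also be read alone, with fluoro held on the aromatic carbon, and methoxy in place of methyl gives a 1.2-fold lower number from compound 1 to compound 3 (0.08 log units; within the scatter), a step within the scatter, so of the two exchanges only the one on the aromatic carbon moves the number measurably in this set. No measurement shown here explains either step.

As far as these compounds go, whether the preference for methyl over fluoro also holds when the carbonyl carbon carries methyl instead of methoxy remains open, as this change has been read with methoxy only. Also open, from the compounds shown here alone, is how chloro or a nitrile would compare on the aromatic carbon, and how an amine would compare on the carbonyl carbon.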